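Benzyl series: one more methyl on the saturated ring

This account rests on a few compounds, and the source may have more. Where it says the series, first, only, none or still open, it means among the compounds named here.

In a functional assay on the whole organism with Rattus norvegicus as the target (on this read-out higher numbers stand for an effect only at larger amounts of compound and lower numbers for an effect already at smaller amounts), compound 1 `COc1cc(N)c(Cl)cc1C(=O)NCC1CCCN1Cc1ccccc1` gives 1.1 mg/kg as the reference point, compound 2 `COc1cc(N)c(Cl)cc1C(=O)NCC1CCC(C)N1Cc1ccccc1` gives 0.67 mg/kg and compound 3 `CNc1cc(OC)c(C(=O)NCC2CCCN2Cc2ccccc2)cc1Cl` gives 0.94 mg/kg on the same read-out. Compound 3 thus stands among three numbers that all lie within the scatter of each other, and no order can be drawn among them.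

The next structure is compound 4 `CNc1cc(OC)c(C(=O)NCC2CCC(C)N2Cc2ccccc2)cc1Cl`, which carries methyl in place of hydrogen on a saturated ring carbon and is otherwise the same as compound 3.

Going by the values given here, the same replacement has been measured once, on the core of compound 1, and gave a 1.6-fold lower number from compound 1 to compound 2 (0.22 log units; within the scatter) as the only direct evidence. Among the compounds with values here, the other measured step, a 1.2-fold lower number from compound 1 to compound 3 (0.07 log units; within the scatter) for methyl in place of hydrogen on a nitrogen on an aromatic ring, also stays within the scatter and offers no sign that the two cores respond differently, though no pair tests this directly.

Carrying the first step over, a small move towards a lower number is expected, with nothing beyond the scatter. The expected step is a 1.6-fold lower number from compound 3 to compound 4 (0.22 log units; within the scatter) and it rests on that single pair. For compound 4 the estimated value is 0.57 mg/kg with an expected range from 0.25 mg/kg to 1.3 mg/kg in this assay on this evidence.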

Compound 4, dose for half-maximal effect: 0.35 mg/kg
For compound 4 the middle estimate is 1.6-fold (0.21 log units) above the measured one; the range from low to high includes it.
By their numbers in this assay, from the lowest: compounds 4, 2, 3 and 1 (each within the scatter of the next, the first and the last beyond it).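

Methyl in place of hydrogen on a saturated ring carbon, next to the ring nitrogen, gives a 2.7-fold lower number from compound 3 to compound 4 (0.43 log units; beyond the scatter) in this assay. Unlike the earlier step on the core of compound 1, this step lies beyond the scatter, so this change at this position now has one modest measured effect behind it. The two steps do not separate the cores, and the data give no sign that the change acts differently on them: the same change on two cores in this assay, a 1.6-fold lower number (0.22 log units; within the scatter) from compound 1 to compound 2 and a 2.7-fold lower number (0.43 log units; beyond the scatter) from compound 3 to compound 4, 1.6-fold (0.21 log units) apart, within the scatter of two such steps.

With the ring methyl present, methyl in place of hydrogen on a nitrogen on an aromatic ring gives a 1.9-fold lower number from compound 2 to compound 4 (0.28 log units; within the scatter) and so remains without a demonstrated effect, and the two readings of that change also agree: the same change on two cores in this assay, a 1.2-fold lower number (0.07 log units; within the scatter) from compound 1 to compound 3 and a 1.9-fold lower number (0.28 log units; within the scatter) from compound 2 to compound 4, 1.6-fold (0.21 log units) apart, within the scatter of two such steps.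

Whether this position tolerates more than methyl stays open, as neither an ethyl group nor a hydroxymethyl group nor an amine on this ring carbon appears among the compounds shown. Also open, on these data alone, is whether the step carries over when a longer alkyl chain stands in place of the benzyl group on the ring nitrogen.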